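Amino to hydrogen on the fused core of compound 1

A few compounds are considered here, and "the series" means these few. Any claim that something is new, unique, unknown or untested is made for them only; others in the source may bear on it.

Three compounds of the series carry a measurement in a functional assay on LOX IMVI cells (Homo sapiens) for cytotoxicity, read by sulforhodamine B assay, with a stated time of 48 h; a higher number here means a weaker inhibitor of growth, a lower number a stronger inhibitor of growth. Compound 1 `Nc1nc(Cl)c2ncn(Cc3ccccc3CCl)c2n1` gives 3890 nM and stands at the highest number of the three. Compound 3 `Nc1nc(Cl)c2ncn(Cc3cccc(CCl)c3)c2n1` sits closest to it: in this assay compound 3 gives 3380 nM, and the gap to compound 1 lies within the scatter, so no order between the two can be read. Compound 2 `ClCc1ccccc1Cn1cnc2nc(Cl)nc(Cl)c21` is the far end: in this assay compound 2 gives 160 nM, a gap to compound 1 that lies well beyond the scatter.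

For the measured compounds named here, no pair of measured compounds differs in a single place, so no measured step is available. The step under consideration leads from compound 1 to compound 4 `ClCc1ccccc1Cn1cnc2c(Cl)ncnc21`, which is yet to be measured in this assay. The change is hydrogen in place of amino on an aromatic carbon.

For this step a move toward a lower number, beyond the scatter, is expected, because compound 2, which also lacks the amino group, gives 160 nM while compound 1 gives 3890 nM. The expected step is a 4.3-fold lower number from compound 1 to compound 4 (0.64 log units; beyond the scatter). For compound 4 the estimate is 900 nM, with a range from 250 nM to 3200 nM.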

Compound 4, concentration for 50% growth inhibition: 2130 nM
Compound 4: middle estimate off by 2.4-fold (0.37 log units), on the low side; the measured number falls inside the stated range.
By their numbers in this assay, from the lowest: compound 2; then compounds 4, 3 and 1 (each within the scatter of the next).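

In this assay the exchange of amino for hydrogen gives a 1.8-fold lower number from compound 1 to compound 4 (0.26 log units; within the scatter), so no order can be read between the two compounds. For the compounds shown here, this is the first single-place step, and it shows that, on the core of compound 1, the aromatic carbon between two ring nitrogen atoms can carry either amino or hydrogen without a difference beyond the scatter. Compound 2, at 160 nM, differs from compound 4 in more than one place, so its number cannot be assigned to the absence of amino alone. No measurement at hand bears on why the step stays this small.

Open, as far as these compounds go, is whether any group at this carbon moves the number beyond the scatter, for example methyl, methoxy or dimethylamino in place of amino or hydrogen. Also open, from the compounds shown here alone, is how much of the number depends on the chloromethyl group, which a plain methyl or a hydroxymethyl in its place on the core of compound 4 would test.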